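Dimethylamino placement: from compound 2 to compound 3

The source may report more compounds than this note shows. Statements on the series, on what has been measured and on what is new or still open speak of the compounds shown alone.

Measured in a physicochemical assay for lipophilicity, measured as octanol-water partition, at pH 7.4; on this read-out lower numbers stand for lower lipophilicity and higher numbers for higher lipophilicity:
Compound 1 `Cc1ccc(-c2c[nH]c(CNc3ccnc4cc(Cl)ccc34)n2)cc1`: 4.66
Compound 2 `CN(C)c1ccc(-c2c[nH]c(CNc3ccnc4cc(Cl)ccc34)n2)cc1`: 4.75

On these two numbers, compound 2, at 4.75, lies within the scatter of compound 1, so no order can be read between them. The next structure is compound 3 `CN(C)c1cccc(-c2c[nH]c(CNc3ccnc4cc(Cl)ccc34)n2)c1`. The change is 3-(dimethylamino)phenyl in place of 4-(dimethylamino)phenyl on an aromatic carbon, with the same atoms joined differently. Among the compounds with values here, only one measured step bears on this, and only indirectly: a number 0.09 log units higher from compound 1 to compound 2 (within the scatter), with dimethylamino in place of methyl on an aromatic carbon. Within the data shown here, that step is a different kind of change, and no measured pair shows a change of the kind now in question. With so little evidence, no step beyond the scatter is expected in this assay, in either direction. The estimated step is a number 0.05 log units lower from compound 2 to compound 3 (within the scatter). For compound 3 the expected value is 4.7, with an estimated range from 4.3 to 5.1.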

Compound 3, distribution coefficient: 5.48
Estimate against measurement, compound 3: 0.78 log units below, outside the stated range (above it).
By their numbers in this assay, from the lowest: compounds 1 and 2 (each within the scatter of the next); then compound 3.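

In this assay the placement of the dimethylamino group now shows an effect on the number, which the swap of methyl for dimethylamino did not: with the same atoms joined differently, 3-(dimethylamino)phenyl in place of 4-(dimethylamino)phenyl gives a number 0.73 log units higher from compound 2 to compound 3 (beyond the scatter) on the same core. The 3-(dimethylamino)phenyl group also stands clear of 4-methylphenyl, with a number 0.82 log units higher from compound 1 to compound 3 (beyond the scatter), so compound 3 is set apart from both earlier compounds, while compound 1 and compound 2 remain within the scatter of each other. No measurement at hand accounts for this difference between the two placements.

On these data alone, it remains open whether the step belongs to dimethylamino itself or would also appear with another group, such as a primary amine or a methoxy group, in the place dimethylamino holds in 3-(dimethylamino)phenyl. As far as these compounds go, with only these three compounds and this single read-out, it also remains open whether the same change of placement would give a step of similar size on a different core or in any other assay.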